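Cytotoxicity notes: benzyl replacement on the shared core

A few compounds are considered here, and "the series" means these few. Any claim that something is new, unique, unknown or untested is made for them only; others in the source may bear on it.

Measured so far:
compound 1 `Cc1ccn(Cc2c(F)cccc2F)c2nc(-c3c(F)cccc3F)nc1-2` — in an ADME assay on MDBK cells (Bos taurus) for cytotoxicity (on this read-out higher numbers stand for lower toxicity in this test and lower numbers for higher toxicity in this test), only a limit, > 100000 nM
compound 2 `COc1cccc(Cn2ccc3nc(-c4ccccc4)nc-3c2)c1` — in this assay only a limit, > 100000 nM

Compound 2 stands at the limit of > 100000 nM in this assay, at which 2 of the 2 values shown sit. Going by the values given here, no pair of measured compounds differing in one place is available, so no measured step sets a direction. Compound 3 `Ic1ccc(Cn2ccc3nc(-c4ccccc4)nc-3c2)cc1` differs from compound 2 by 4-iodophenyl in place of 3-methoxyphenyl on a saturated chain carbon bound to an aromatic nitrogen. The step of a number no higher from compound 2 to compound 3 (the limit leaves the size open) is expected to show no change beyond the scatter. Compound 3 is expected at 100000 nM, within 40000 nM to 250000 nM, most likely again reported only as a limit.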

Compound 3, half-maximal cytotoxic concentration: 22000 nM
Compound 3: the middle estimate sits 4.5-fold (0.66 log units) above what was measured, and the stated range ends above it.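

In this assay, the group on a saturated chain carbon bound to an aromatic nitrogen can move the read-out on the shared core: 4-iodophenyl in place of 3-methoxyphenyl gives an at least 4.5-fold lower number from compound 2 to compound 3 (0.65 log units; beyond the scatter). Going by these compounds alone, compound 3 is the first compound here with a value that is not a limit. The true size of the step remains unknown, as the value for compound 2 is only a limit: the limit of > 100000 nM in this assay, at which 2 of the 3 values shown sit.

Which feature of the change carries the step remains open, since the iodine and the methoxy group do not sit at the same ring position. As far as these compounds go, how a plain phenyl or an aminophenyl group would read at this place is also open.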